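Swapping the aryl group on the piperazine nitrogen

This account rests on a few compounds, and the source may have more. Where it says the series, first, only, none or still open, it means among the compounds named here.

Of the compounds shown here, three sharing one core have been measured in an assay on CHO cells for displacement of a labelled ligand from adenosine receptor A3 (Homo sapiens), read by scintillation counting, with a stated time of 45 min, tested at 1 uM, in the presence of a further agent that is not named here; on this read-out lower numbers stand for less inhibition and higher numbers for more inhibition at the one concentration tested (going by the name of the read-out). Compound 1 `CCCn1c(=O)[nH]c2nc(-c3ccc(S(=O)(=O)N4CCN(Cc5cccc(C)c5)CC4)cc3)[nH]c2c1=O` gives 17%, compound 2 `CCCn1c(=O)[nH]c2nc(-c3ccc(S(=O)(=O)N4CCN(Cc5cccc(Br)c5)CC4)cc3)[nH]c2c1=O` gives 23%, and compound 3 `CCCn1c(=O)[nH]c2nc(-c3ccc(S(=O)(=O)N4CCN(c5cccc(F)c5)CC4)cc3)[nH]c2c1=O` gives 44%. Compound 3 therefore stands highest of the three, with the nearest value, that of compound 2, beyond the scatter below it a number 21 percentage points higher from compound 2 to compound 3 (beyond the scatter), and that of compound 1 further still a number 27 percentage points higher from compound 1 to compound 3 (beyond the scatter). Among the measured compounds shown here, the one change between compound 1 and compound 2, bromo in place of methyl on an aromatic carbon, produced a number 6 percentage points higher from compound 1 to compound 2 (within the scatter).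

Compound 4 `CCCn1c(=O)[nH]c2nc(-c3ccc(S(=O)(=O)N4CCN(c5ccc(I)cc5)CC4)cc3)[nH]c2c1=O` is not yet measured. It differs from compound 3 as follows: 4-iodophenyl in place of 3-fluorophenyl on an amine nitrogen in a ring. This keeps the aromatic ring directly on the ring nitrogen, which is the feature that set compound 3 apart from compound 1 and compound 2, and alters only the halogen and where it sits. For the measured compounds named here, the nearest precedent for a halogen swap alone is the step from compound 1 to compound 2, which stayed within the scatter. The expectation for compound 4 is therefore a step of a number 1 percentage points higher from compound 3 to compound 4 (within the scatter), that is, nothing beyond the scatter. Compound 4 is estimated at 45%, with a range from 25% to 65%.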

Compound 4, a percentage reported as inhibition, at one concentration (the size of the read-out at that concentration, not a potency): 36%
Estimate against measurement, compound 4: 9 percentage points above, and the stated range covers the measured number.
By their numbers in this assay, from the lowest: compounds 1 and 2 (each within the scatter of the next); then compounds 4 and 3 (each within the scatter of the next).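

Replacing 3-fluorophenyl with 4-iodophenyl on the amine nitrogen in the ring gives a number 8 percentage points lower from compound 3 to compound 4 (within the scatter) in this assay, so at this position the halogen and its place on the aromatic ring can change together without a shift that stands clear of the usual variation. The gaps to the two benzyl compounds also hold for this second halogen-bearing phenyl, with a number 13 percentage points higher from compound 2 to compound 4 (beyond the scatter) and a number 19 percentage points higher from compound 1 to compound 4 (beyond the scatter); among these four compounds, both with the aromatic ring directly on the nitrogen read higher than both with 3-bromobenzyl or 3-methylbenzyl there, and none goes against this. No measurement at hand explains this difference between the phenyl and benzyl groups.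

The halogen and its place on the ring differ together between the two phenyl compounds, so the contribution of each remains unseparated, and 4-fluorophenyl or 3-iodophenyl would be needed to pull them apart. Going by these compounds, how an unsubstituted phenyl, or a phenyl carrying a methoxy group or a carboxylic acid, would compare at this nitrogen also remains open.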